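This account rests on a few compounds, and the source may have more. Where it says the series, first, only, none or still open, it means among the compounds named here.

Within the data shown here, in a functional assay on HT-29 cells (Homo sapiens) for cytotoxicity, read by MTT assay, with a stated time of 72 h (on this read-out lower numbers stand for stronger inhibition and higher numbers for weaker inhibition), compound 2 `COc1ccc(-c2nn(-c3ccccc3)cc2C(=O)Nc2nc3ccc(Cl)cc3s2)cc1` gives 6570 nM, the only number among the two values shown. Compound 1 `COc1ccc2nc(NC(=O)c3cn(-c4ccccc4)nc3-c3ccccc3)sc2c1` carries the same 6-methoxy-1,3-benzothiazol-2-yl group as compound 3. In this assay compound 1 reaches only a limit of the assay, > 50000 nM. The evidence thus amounts to the limit of > 50000 nM in this assay, at which 1 of the 2 values shown sits. Compound 3 `COc1ccc(-c2nn(-c3ccccc3)cc2C(=O)Nc2nc3ccc(OC)cc3s2)cc1` differs from compound 2 by methoxy in place of chloro on an aromatic carbon. Among the measured compounds shown here, no step between measured compounds covers this change; the move is expected to weaken inhibition beyond the usual scatter, as a 3.0-fold higher number from compound 2 to compound 3 (0.48 log units; beyond the scatter). Compound 3 is estimated at 20000 nM in this assay, within a range from 6000 nM to 60000 nM.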

Compound 3, half-maximal inhibitory concentration: > 50000 nM
Compound 3: a limit, no number (the forecaster's own chance of this, stated with the estimate: 35%); middle value at least 2.5-fold (0.39 log units) away from the limit.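

In this assay, 6-methoxy-1,3-benzothiazol-2-yl in place of 6-chloro-1,3-benzothiazol-2-yl gives an at least 7.6-fold higher number from compound 2 to compound 3 (0.88 log units; beyond the scatter), so the result at this position depends on the group carried there. Compound 3 stands at a limit of the assay, > 50000 nM. The step between compound 1 and compound 3 cannot be read, as both values are limits: the limit of > 50000 nM in this assay, at which 2 of the 3 values shown sit.

On these data alone, it remains open how a fluoro group, a nitrile or an amine on this aromatic carbon would read. As far as these compounds go, it is also open whether any such group would give a lower number than compound 2 at 6570 nM.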